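Aryl swap on the sulfur linker of compound 2

This account rests on a few compounds, and the source may have more. Where it says the series, first, only, none or still open, it means among the compounds named here.

Three analogues of the shared core carry numbers in a functional assay on A498 cells (Homo sapiens) for inhibition, read by sulforhodamine B assay, with a stated time of 48 h; a higher number here means a weaker inhibitor of growth, a lower number a stronger inhibitor of growth. Compound 1 `COc1cc(CNc2nc3cc(N)cc(N)c3nc2-c2ccccc2)cc(OC)c1OC` gives 14800 nM in this assay. Compound 3 `CCOC(=O)[C@H](CCC(=O)O)NC(=O)c1ccc(Oc2nc3cc(N)cc(N)c3nc2-c2ccccc2)cc1` gives 14800 nM in this assay. Compound 2 `Nc1cc(N)c2nc(-c3ccccc3)c(Sc3ccc(Cl)c(Cl)c3)nc2c1` gives 30900 nM in this assay, the highest of the three; its gaps to compound 1 and to compound 3 lie beyond the scatter, so compound 2 is the weakest inhibitor of growth here. Among the measured compounds shown here, no measured pair differs in one place, so no step of known size is available. Compound 4 `COc1ccc(Sc2nc3cc(N)cc(N)c3nc2-c2ccccc2)cc1` is not yet measured and differs from compound 2 thus: 4-methoxyphenyl in place of 3,4-dichlorophenyl on a sulfur. Compound 4 is expected to give a modestly lower number, estimated at 20000 nM with a range of 8000 nM to 50000 nM. The expected step of a 1.5-fold lower number from compound 2 to compound 4 (0.19 log units; within the scatter) is small, possibly within the scatter.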

Compound 4, concentration for total growth inhibition: 32400 nM
The estimate for compound 4 lay 1.6-fold (0.21 log units) below the measured number, within the range that was stated.
By their numbers in this assay, from the lowest: compounds 1 and 3 (each within the scatter of the next); then compounds 2 and 4 (each within the scatter of the next).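

Among the compounds shown here, this is the first step of known size at this position: in this assay, 4-methoxyphenyl in place of 3,4-dichlorophenyl on a sulfur gives a 1.0-fold higher number from compound 2 to compound 4 (0.02 log units; within the scatter), so the two aryl groups cannot be told apart here. Two aromatic substituent patterns, one with chlorine and one with an oxygen that adds a hydrogen-bond acceptor, thus read alike on this sulfur. No measurement on hand explains this result.

Going by these compounds, whether a carboxylic acid or an amine on the aryl ring on a sulfur would read differently stays open. So does the effect of a longer chain in place of the aryl ring.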